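Permeability notes on a 4-aminoquinoline-derived diamine series

The compounds below may be only part of what the source reports. "The series", "measured", "known", "first", "only" and "open" are said of these compounds alone.

Measured so far:
- compound 1 `COc1ccc(F)cc1CNCCCNc1ccnc2cc(Cc3ccc(C#N)cc3)ccc12`: 23 10^-6 cm/s
- compound 2 `COc1ccc(F)cc1CNCCCNc1ccnc2cc(-c3cccc4ccccc34)ccc12`: 237 10^-6 cm/s
- compound 3 `N#Cc1ccc(Cc2ccc3c(NCCCNCc4ccco4)ccnc3c2)cc1`: 23 10^-6 cm/s

In an ADME assay for permeability, using PAMPA, with a stated time of 30 min, at pH 7.4 (a lower number here means that the compound crosses the layer more slowly, a higher number that the compound crosses the layer faster), compound 1 gives 23 10^-6 cm/s. Compound 2 differs from compound 1 by naphthalen-1-yl in place of 4-cyanobenzyl on an aromatic carbon and this change gives a 10-fold higher number from compound 1 to compound 2 (1.01 log units; beyond the scatter). Compound 3 differs from compound 1 by furan-2-yl in place of 5-fluoro-2-methoxyphenyl on a saturated chain carbon bound to an amine nitrogen; in this assay compound 3 gives 23 10^-6 cm/s, so that no change at the digits printed from compound 1 to compound 3 (within the scatter).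

Compound 4 `c1coc(CNCCCNc2ccnc3cc(-c4cccc5ccccc45)ccc23)c1` has not yet been measured. It differs from compound 3 by naphthalen-1-yl in place of 4-cyanobenzyl on an aromatic carbon, the same change already seen from compound 1 to compound 2, and the place of the change is described in the same words for both pairs. The two cores differ as set out for compound 1 and compound 3, where the exchange left the number unchanged within the scatter.

For the measured compounds named here, on this basis the step from compound 3 to compound 4 is expected to be about as large as the earlier one, estimated as a 10-fold higher number from compound 3 to compound 4 (1.00 log units; beyond the scatter), because the only precedent, a 10-fold higher number from compound 1 to compound 2 (1.01 log units; beyond the scatter), is a large step well beyond the scatter. Compound 4 is thus expected to give about 230 10^-6 cm/s, with a likely range from 100 10^-6 cm/s to 500 10^-6 cm/s. Going by the values given here, only one example of this change exists, so the estimate is uncertain.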

Compound 4, apparent permeability: 237 10^-6 cm/s
The estimate for compound 4 lay 1.0-fold (0.01 log units) below the measured number, within the range that was stated.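

In this assay the exchange of 4-cyanobenzyl for naphthalen-1-yl carried from one core to the other, with a 10-fold higher number from compound 3 to compound 4 (1.01 log units; beyond the scatter) matching the earlier step: the same change on two cores in this assay, a 10-fold higher number (1.01 log units; beyond the scatter) from compound 1 to compound 2 and a 10-fold higher number (1.01 log units; beyond the scatter) from compound 3 to compound 4, 1.0-fold (0.00 log units) apart, within the scatter of two such steps. The exchange of 5-fluoro-2-methoxyphenyl for furan-2-yl read the same way on the naphthalen-1-yl compounds as on the 4-cyanobenzyl compounds, with no change at the digits printed from compound 2 to compound 4 (within the scatter): the same change on two cores in this assay, no change at the digits printed (within the scatter) from compound 1 to compound 3 and no change at the digits printed (within the scatter) from compound 2 to compound 4, 1.0-fold (0.00 log units) apart, within the scatter of two such steps. These four compounds show that the two changes acted independently of each other here, but they form a single square, so they do not show which feature of naphthalen-1-yl goes with the large step, nor that the result extends past these two cores.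

As far as these compounds go, it remains open whether the same step would appear with other groups on that aromatic carbon, such as a carboxylic acid or a morpholine. From the compounds shown here alone, a longer chain linking the two amine nitrogens also remains untested as a third core for carrying either change.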